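Aryl variation on the oxadiazole sulfide of a thiazolidinedione series

The source may hold more compounds than are shown below. What is called first, only, known or untested is meant among the compounds shown, and "the series" means these compounds.

Measured so far in a functional assay on the whole organism (strain Wistar) with Rattus norvegicus as the target, with a stated time of 15 days, at a dose of 30 mg/kg by the oral route; on this read-out lower numbers stand for a weaker effect and higher numbers for a stronger effect at the one dose given:
- compound 1 `O=C1NC(=O)/C(=C/c2ccc(OCCSc3nnc(-c4ccc([N+](=O)[O-])cc4)[nH]3)cc2)S1` gives 18.6%
- compound 2 `O=C1NC(=O)/C(=C/c2ccc(OCCSc3nnc(-c4ccccc4)o3)cc2)S1` gives 24.1%
- compound 3 `O=C1NC(=O)/C(=C/c2ccc(OCCSc3nnc(Cc4ccccc4)o3)cc2)S1` gives 28%

Compound 3 holds the highest of the three numbers in this assay, but its lead is small: compound 2 sits nearest and compound 1 furthest, and both gaps are within the scatter, so no order among the three can be read from these values. Within the data shown here, the one step between compounds that differ in a single place, a number 3.9 percentage points higher from compound 2 to compound 3 (within the scatter), is itself within the scatter.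

Compound 4 `O=C1NC(=O)/C(=C/c2ccc(OCCSc3nnc(-c4ccncc4)o3)cc2)S1` has not been measured. It differs from compound 3 as follows: pyridin-4-yl in place of benzyl on an aromatic carbon. Among the measured compounds shown here, no measured step matches this change; the only step that bears on it is the exchange of the group at the same position of the shared core, from compound 2 to compound 3, which moved the read-out by an amount within the scatter. On that basis, and with all three measured values lying in a narrow band, no step beyond the scatter is expected from compound 3 to compound 4, in either direction. Compound 4 is therefore expected to give about 24% in this assay, somewhere between 13% and 35%. The estimated step of a number 4 percentage points lower from compound 3 to compound 4 (within the scatter) is expected to stay within the scatter.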

Compound 4, a percentage reported as activity, at one dose (the size of the read-out at that dose, not a potency): 58.5%
Compound 4: middle estimate off by 34.5 percentage points, on the low side, and the stated range ends below it.
By their numbers in this assay, from the lowest: compounds 1, 2 and 3 (each within the scatter of the next); then compound 4.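

In this assay, the position on the aromatic carbon of the five-membered ring looked insensitive while only phenyl and benzyl had been compared there, but it proves able to carry a large change: pyridin-4-yl in place of benzyl gives a number 30.5 percentage points higher from compound 3 to compound 4 (beyond the scatter), and pyridin-4-yl in place of phenyl gives a number 34.4 percentage points higher from compound 2 to compound 4 (beyond the scatter). The step from phenyl is the tighter comparison, as both groups are six-membered aromatic rings and pyridin-4-yl holds one hetero atom, a nitrogen counted as a hydrogen-bond acceptor, so this one ring nitrogen goes with a step that benzyl in place of phenyl did not produce. Nothing available accounts for the size of this step.

The compounds shown leave open whether the step depends on where the nitrogen sits in the ring, as pyridin-3-yl or pyridin-2-yl would show, or whether it extends to a pyrimidine ring or to a phenyl ring bearing an amine. With a read-out at one dose only, the order of these compounds in this assay also says nothing about their potency.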